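The compounds below may be only part of what the source reports. "The series", "measured", "known", "first", "only" and "open" are said of these compounds alone.

Measured compounds:
compound 1 `CC(C)=CCC[C@]1(C)/C=C/[C@@H](OC(=O)C=C(C)C)[C@](C)(O)/C=C/C(=O)/C(CN2CCCC2)=C\C1` gives 220 nM in a functional assay on MCF7 cells (Homo sapiens) for antiproliferative activity, read by MTT assay, with a stated time of 48 h; a higher number here means a weaker inhibitor, a lower number a stronger inhibitor;
compound 2 `CC(C)=CCC[C@](C)(/C=C/[C@@H](OC(=O)C=C(C)C)[C@](C)(O)/C=C/C(=O)/C=C/N(C)C)CC=O` gives 12200 nM in this assay.

Compound 1 holds the lowest of the two numbers in this assay, and its distance to compound 2 lies beyond the scatter. Compound 3 `CCN(CC)C(=O)/C1=C/C[C@](C)(CCC=C(C)C)/C=C/[C@@H](OC(=O)C=C(C)C)[C@](C)(O)/C=C/C1=O` has not yet been measured in this assay. It differs from compound 1 by diethylcarbamoyl in place of (pyrrolidin-1-yl)methyl on a double-bonded ring carbon, a change on a double-bonded ring carbon of the core of compound 1. Among the compounds with values here, no step between measured compounds of this kind is available, so the expected step from compound 1 to compound 3 is uncertain; a moderate weakening, a 3.6-fold higher number from compound 1 to compound 3 (0.56 log units; beyond the scatter), is estimated. Compound 3 is therefore expected at about 800 nM, within 150 nM to 5000 nM.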

Compound 3, half-maximal inhibitory concentration: 12100 nM
The estimate for compound 3 lay 15-fold (1.18 log units) below the measured number, outside the stated range (above it).
By their numbers in this assay, from the lowest: compound 1; then compounds 3 and 2 (each within the scatter of the next).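

The double-bonded ring carbon of the shared core proves highly sensitive to this change: diethylcarbamoyl in place of (pyrrolidin-1-yl)methyl gives a 55-fold higher number from compound 1 to compound 3 (1.74 log units; beyond the scatter) in this assay and so abolishes most of the activity of compound 1. Compound 3 thus shows that this position does not accept any nitrogen-bearing group equally. Nothing available explains the size of this step.

From the compounds shown here alone, it remains open whether the loss follows the carbonyl or the open diethyl chain. A (diethylamino)methyl group or a (pyrrolidin-1-yl)carbonyl group on this carbon would separate the two.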